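Shifting the hydroxyl along the triazole side chain

The source may report more compounds than this note shows. Statements on the series, on what has been measured and on what is new or still open speak of the compounds shown alone.

Compound 2 `OCCCc1cn(CCNc2nonc2/C(=N/O)Nc2ccc(F)c(Br)c2)nn1` is the reference point. Among the compounds with values here, in an assay on isolated protein for inhibition of Indoleamine 2,3-dioxygenase 2 (Homo sapiens) (on this read-out lower numbers stand for stronger inhibition and higher numbers for weaker inhibition), compound 2 gives 958 nM; the only other number, that of compound 1 `CC(C)(C)c1cn(CCNc2nonc2/C(=N/O)Nc2ccc(F)c(Br)c2)nn1`, lies within the scatter of it at 1870 nM. Within the data shown here, the single measured step, a 2.0-fold lower number from compound 1 to compound 2 (0.29 log units; within the scatter), touches the same aromatic carbon but exchanges a different pair of groups. Compound 3 `CCC(O)c1cn(CCNc2nonc2/C(=N/O)Nc2ccc(F)c(Br)c2)nn1` differs from compound 2 by 1-hydroxypropyl in place of 3-hydroxypropyl on an aromatic carbon. Among the measured compounds shown here, with that one step within the scatter and no closer precedent, no change beyond the scatter is expected for a 1.0-fold higher number from compound 2 to compound 3 (0.02 log units; within the scatter). Compound 3 is therefore estimated at 1000 nM, between 400 nM and 2500 nM.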

Compound 3, half-maximal inhibitory concentration: 947 nM
For compound 3 the middle estimate is 1.1-fold (0.02 log units) above the measured one, and the stated range covers the measured number.
By their numbers in this assay, from the lowest: compounds 3, 2 and 1 (each within the scatter of the next).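

In this assay, 1-hydroxypropyl in place of 3-hydroxypropyl on this aromatic carbon gives a 1.0-fold lower number from compound 2 to compound 3 (0.01 log units; within the scatter), so moving the hydroxyl along the chain does not register on this read-out. The comparison with tert-butyl also stays inside the scatter, at a 2.0-fold lower number from compound 1 to compound 3 (0.30 log units; within the scatter), and the position has yet to show a real difference between groups. No measurement on hand accounts for this flat result.

Still open, as far as these compounds go, is whether an amine, a carboxylic acid or a longer hydroxyalkyl chain on this carbon would move the number beyond the scatter.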